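The compounds below may be only part of what the source reports. "The series", "measured", "known", "first", "only" and "open" are said of these compounds alone.

In a functional assay on CLL cells (Homo sapiens) for cytotoxicity, read by MTT assay, with a stated time of 48 h (a higher number here means that more compound is needed for the effect, a lower number that less compound is needed), compound 1 `C=C(CC)C(=O)c1ccc(OCC(=O)Nc2ccc(C(C)=O)cc2)c(Cl)c1Cl` gives 3900 nM and compound 2 `C=C(CC)C(=O)c1ccc(OCC(=O)Nc2ccc(O)cc2)c(Cl)c1Cl` gives 6400 nM. For the measured compounds named here, the only measured step between them is a 1.6-fold higher number from compound 1 to compound 2 (0.22 log units; within the scatter), so compound 2 cannot be told apart from compound 1. Compound 3 `C=C(CC)C(=O)c1ccc(OCC(=O)NO)c(Cl)c1Cl` comes from compound 2 by a single change: hydroxy in place of 4-hydroxyphenyl on an amide-type nitrogen. The measured step offers only indirect guidance, since it exchanged one group on an aromatic carbon, whereas here the whole 4-hydroxyphenyl leaves. Going by the values given here, no measurement yet covers such a change. Going by that small step alone, a shift beyond the scatter is not expected, with only a slight lean towards a higher number. For compound 3 the estimated step is a 1.3-fold higher number from compound 2 to compound 3 (0.10 log units; within the scatter). Compound 3 is expected at 8000 nM, with an estimated range from 2500 nM to 25000 nM.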

Compound 3, half-maximal effective concentration: 4500 nM
Compound 3: the middle estimate sits 1.8-fold (0.25 log units) above what was measured, and the stated range covers the measured number.
By their numbers in this assay, from the lowest: compounds 1, 3 and 2 (each within the scatter of the next).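

In this assay, the earlier step changed only a group on the aromatic ring, whereas here the entire ring leaves the amide-type nitrogen, and the result is a 1.4-fold lower number from compound 2 to compound 3 (0.15 log units; within the scatter) with hydroxy in its place. Set against the acetyl-bearing compound, the same kind of exchange gives a 1.2-fold higher number from compound 1 to compound 3 (0.06 log units; within the scatter) and thus also stays within the scatter. At this position, then, these three compounds cannot be told apart whether the nitrogen carries 4-hydroxyphenyl, 4-acetylphenyl or hydroxy, although nothing here explains that outcome. It remains open whether hydroxy itself matters, since a plain amide hydrogen, a methoxy or an amino group on this nitrogen is not among the compounds shown. Also open, going by these compounds, is whether a longer alkyl chain here, or a change to the shared core, would move the number beyond the scatter.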